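Swapping the Amine Heteroaryl: Pyrazole to Thiadiazole

The source may report more compounds than this note shows. Statements on the series, on what has been measured and on what is new or still open speak of the compounds shown alone.

Compound 3 `Cc1ccc(CNC(=O)c2cccc(C(C)Oc3cccnc3Nc3cnn(CC#N)c3)c2)cc1` belongs to a set of three analogues sharing one core, differing in the small heteroaromatic ring attached to an amine nitrogen. In a functional assay on NCI-H3122 cells (Homo sapiens) for antiproliferative activity, read by MTT assay, with a stated time of 48 h (a lower number here means a stronger inhibitor, a higher number a weaker inhibitor), compound 3 gives 38400 nM, the highest of the two numbers measured, though compound 1 `CC(Oc1cccnc1Nc1cnn(C)c1)c1cccc(C(=O)NCc2ccc(F)c(Cl)c2)c1` with 35700 nM sits within the scatter of it. Compound 2 `Cc1ccc(CNC(=O)c2cccc(C(C)Oc3cccnc3Nc3ncccn3)c2)cc1` reaches only a limit, > 100000 nM, described by the limit of > 100000 nM in this assay, at which 1 of the 3 values shown sits. Going by the values given here, the single measured step, an at least 2.6-fold lower number from compound 2 to compound 3 (0.41 log units; beyond the scatter), is the only guide. Compound 4 `Cc1ccc(CNC(=O)c2cccc(C(C)Oc3cccnc3Nc3nncs3)c2)cc1` changes the same position: 1,3,4-thiadiazol-2-yl in place of 1-(cyanomethyl)-1H-pyrazol-4-yl on a nitrogen on an aromatic ring. This resembles a move back toward compound 2, so compound 4 is expected to be weaker, around 70000 nM, ranging from 25000 nM to 150000 nM. The step of a 1.8-fold higher number from compound 3 to compound 4 (0.26 log units; within the scatter) is expected to weaken activity, possibly to a limit.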

Compound 4, half-maximal inhibitory concentration: 20800 nM
Estimate against measurement, compound 4: 3.4-fold (0.53 log units) above, and the stated range ends above it.
By their numbers in this assay, from the lowest: compounds 4, 1 and 3 (each within the scatter of the next). At a limit, above all of these: compound 2.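

Replacing the pyrazole with 1,3,4-thiadiazol-2-yl on this amine nitrogen gives a 1.8-fold lower number from compound 3 to compound 4 (0.27 log units; within the scatter), so this position accepts a second kind of five-membered ring, one that carries sulfur and no nitrile. Measured against pyrimidin-2-yl, the same ring gives an at least 4.8-fold lower number from compound 2 to compound 4 (0.68 log units; beyond the scatter), which means that the pyrazole is not alone in clearing compound 2. That step is only a minimum, as compound 2 stands at a limit: the limit of > 100000 nM in this assay, at which 1 of the 4 values shown sits.

As far as these compounds go, whether 1,3,4-oxadiazol-2-yl, with oxygen in place of sulfur, or thiazol-2-yl would behave like the thiadiazole remains open.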